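A few compounds are considered here, and "the series" means these few. Any claim that something is new, unique, unknown or untested is made for them only; others in the source may bear on it.

Three close relatives of one small core have been tested in a functional assay on HEp-2 cells (Homo sapiens) for cytotoxicity, read by MTT assay, with a stated time of 72 h, tested at 10 ug/mL; a lower number here means less inhibition of growth, a higher number more inhibition of growth at the concentration tested. Compound 1, `O=C1NC(=S)/C(=C/c2ccc(Cl)cc2)S1`, gives 22.3%. Compound 2, `O=C1NC(=S)/C(=C/c2ccccc2Cl)S1`, gives 21.2%; the difference between the cores of compound 1 and compound 2 is not broken down here, and the two numbers lie within the scatter of each other. Compound 3, `O=C1NC(=S)/C(=C/c2ccc(Cl)c(Cl)c2)S1`, gives 16.4%. The change from compound 1 to compound 3 is chloro in place of hydrogen on an aromatic carbon, placed ortho to a chloro group and meta to a group of 8 heavy atoms, and its step was a number 5.9 percentage points lower from compound 1 to compound 3 (within the scatter).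

Compound 4, `O=C1NC(=S)/C(=C/c2c(Cl)cccc2Cl)S1`, has not yet been measured. It arises from compound 2 by the same kind of change, (chloro in place of hydrogen on an aromatic carbon), but here the new chloro sits ortho to the group of 8 heavy atoms and meta to a chloro group. Because the earlier step was a number 5.9 percentage points lower from compound 1 to compound 3 (within the scatter), the step from compound 2 to compound 4 is expected to be small as well, about a number 3.2 percentage points lower from compound 2 to compound 4 (within the scatter). Compound 4 is therefore estimated to give 18% in this assay, most likely between 8% and 30%.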

Compound 4, percent growth inhibition at one concentration: 8.73%
Compound 4: middle estimate off by 9.3 percentage points, on the high side; low and high end bracket the measured number.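

In this assay, the new step is a number 12.5 percentage points lower from compound 2 to compound 4 (beyond the scatter), so this added chloro, ortho to a group of 8 heavy atoms and meta to a chloro group, goes with less inhibition of growth at the concentration tested. Set beside the earlier step, the same change lowers the number on both cores, and the two steps cannot be told apart: the same change on two cores in this assay, a number 5.9 percentage points lower (within the scatter) from compound 1 to compound 3 and a number 12.5 percentage points lower (beyond the scatter) from compound 2 to compound 4, 6.6 percentage points apart, within the scatter of two such steps This supports expecting a similar step when the change is carried between these two cores, but it rests on just one pair of steps, only the new one lies beyond the scatter, and the added chloro sits at a different place in each pair, so neither a general rule nor any reason for the drop is shown.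

The aromatic rings shown carry only chloro and hydrogen. On these data alone, how a methoxy group, an amine or a carboxylic acid in those places would read in this assay remains open.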